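A few compounds are considered here, and "the series" means these few. Any claim that something is new, unique, unknown or untested is made for them only; others in the source may bear on it.

In a functional assay on the whole organism with Canis familiaris (Canis lupus familiaris) as the target, at a dose of 2 mg/kg by the oral route (on this read-out higher numbers stand for a stronger effect at the one dose given and lower numbers for a weaker effect), the measured compounds stand as follows:

Compound 1, `Cc1nc2c(OCc3ccccc3)cccn2c1N`: 50%
Compound 2, `Cc1nc2c(OCc3ccccc3F)cccn2c1N`: 20%
Compound 3, `Cc1nc2c(OCc3cccs3)cccn2c1N`: 30%

Compound 3 stands second highest of the three numbers. Its nearest neighbour is compound 2, whose value lies within the scatter of that of compound 3, so no order can be read between the two. Compound 1 stands furthest away, and the step of a number 20 percentage points lower from compound 1 to compound 3 (beyond the scatter) lies beyond the scatter.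

The next compound, compound 4, `Cc1nc2c(OCc3ccsc3)cccn2c1N`, has the same atoms as compound 3 joined differently: thiophen-3-yl in place of thiophen-2-yl on a saturated chain carbon bound to an oxygen on an aromatic ring.

For the measured compounds named here, no measured step exchanges one thiophenyl for another, so nothing bears directly on this change. Going by the values given here, the one step that touches the same place is a number 20 percentage points lower from compound 1 to compound 3 (beyond the scatter), which exchanged the whole ring for a different ring and moved the number by a modest amount. The step of a number 30 percentage points lower from compound 1 to compound 2 (beyond the scatter) concerns a fluoro on the phenyl of compound 1 and does not bear on compound 4. Moving the point of attachment within an otherwise identical ring is a smaller change than either, so no step beyond the scatter is expected in this assay, in either direction.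

Compound 4 is therefore estimated at 30%, within a range from 10% to 55%. The expected step is no change at the digits printed from compound 3 to compound 4 (within the scatter).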

Compound 4, a percentage reported as inhibition, in the whole organism at one dose (the size of the read-out at that dose, not a potency): 29%
Compound 4: the middle estimate sits 1 percentage points above what was measured; low and high end bracket the measured number.
By their numbers in this assay, from the lowest: compounds 2, 4 and 3 (each within the scatter of the next); then compound 1.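

In this assay, moving the point of attachment within the thiophene ring does not register: thiophen-3-yl in place of thiophen-2-yl gives a number 1 percentage points lower from compound 3 to compound 4 (within the scatter). The earlier compounds shown here left open whether the drop seen on leaving the phenyl of compound 1 belonged to one particular attachment of the thiophene ring, and the new step, a number 21 percentage points lower from compound 1 to compound 4 (beyond the scatter), shows that it appears with both thiophenyl groups, with the same modest label as a number 20 percentage points lower from compound 1 to compound 3 (beyond the scatter). Nothing in hand accounts for the separation of the phenyl from the two thiophenyl groups, or for the absence of a difference between those two.

From the compounds shown here alone, it remains open whether a furan-2-yl or a pyridin-3-yl group on the same saturated chain carbon would stand with the thiophenyl groups or with the phenyl of compound 1. Also open, going by these compounds, is how a longer chain in place of that single carbon would read, and since every number here comes from one dose, the read-out cannot show whether compound 3 and compound 4 would stay together at other doses.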